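Chloro for fluoro on the outer aryl ring

This account rests on a few compounds, and the source may have more. Where it says the series, first, only, none or still open, it means among the compounds named here.

Compound 2 `C=CCn1c(=O)/c(=C\c2cccc(F)c2)[nH]c(=O)/c1=C\c1ccccc1OC` gives 13700 nM in a functional assay on MCF7 cells (Homo sapiens) for cytotoxicity, read by CCK-8 assay, with a stated time of 72 h (on this read-out higher numbers stand for weaker inhibition and lower numbers for stronger inhibition), the second highest of the three numbers measured: nearest to compound 1 `C=CCn1c(=O)/c(=C\c2cccc(C)c2)[nH]c(=O)/c1=C\c1ccccc1OC`, which gives 20700 nM, and furthest from compound 3 `C=CCn1c(=O)/c(=C\c2cc(F)ccc2C)[nH]c(=O)/c1=C\c1ccccc1OC`, which gives 3100 nM. The step of a 1.5-fold lower number from compound 1 to compound 2 (0.18 log units; within the scatter) lies within the scatter, whereas a 4.4-fold lower number from compound 2 to compound 3 (0.65 log units; beyond the scatter) and a 6.7-fold lower number from compound 1 to compound 3 (0.82 log units; beyond the scatter) lie beyond it. Compound 4 `C=CCn1c(=O)/c(=C\c2cccc(Cl)c2)[nH]c(=O)/c1=C\c1ccccc1OC` differs from compound 2 by chloro in place of fluoro on an aromatic carbon. The measured step that bears on this change is a 1.5-fold lower number from compound 1 to compound 2 (0.18 log units; within the scatter), where exchanging one small group for another on that aromatic carbon left the number essentially unchanged. The larger steps to compound 3 come from methyl entering elsewhere and do not speak to a halogen swap. Exchanging one halogen for another on that carbon is therefore expected to shift the number little, if at all, beyond the scatter. The expected step is a 1.1-fold lower number from compound 2 to compound 4 (0.06 log units; within the scatter). Compound 4 is estimated at 12000 nM in this assay, within a range from 5000 nM to 30000 nM.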

Compound 4, half-maximal inhibitory concentration: 5200 nM
Estimate against measurement, compound 4: 2.3-fold (0.36 log units) above; the measured number falls inside the stated range.
By their numbers in this assay, from the lowest: compounds 3 and 4 (each within the scatter of the next); then compounds 2 and 1 (each within the scatter of the next).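

Chloro in place of fluoro on this aromatic carbon gives a 2.6-fold lower number from compound 2 to compound 4 (0.42 log units; beyond the scatter) in this assay and chloro in place of methyl gives a 4.0-fold lower number from compound 1 to compound 4 (0.60 log units; beyond the scatter) while fluoro in place of methyl gave only a 1.5-fold lower number from compound 1 to compound 2 (0.18 log units; within the scatter) so this position separates chloro from the other two groups, which the earlier pair could not show. Set against the 5-fluoro-2-methylphenyl group, the 3-chlorophenyl group gives a 1.7-fold higher number from compound 3 to compound 4 (0.22 log units; within the scatter) so a single chloro reaches the range earlier seen only with that group. Nothing available here explains why chloro parts from fluoro and methyl on this carbon. Going by these compounds, whether bromo, methoxy or an amine on this carbon would read like chloro stays open. So does what chloro would do alongside the methyl of compound 3.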